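A few compounds are considered here, and "the series" means these few. Any claim that something is new, unique, unknown or untested is made for them only; others in the source may bear on it.

Measured so far in a functional assay on MDA-MB-231 cells (Homo sapiens) for inhibition, read by MTT assay, with a stated time of 72 h; on this read-out lower numbers stand for stronger inhibition and higher numbers for weaker inhibition:

compound 1, `O=C(CSc1nc(Nc2ccccc2)c2ccccc2n1)Nc1ccccc1Cl`: 24400 nM
compound 2, `CCc1cccc(NC(=O)CSc2nc(Nc3ccccc3)c3ccccc3n2)c1`: 12400 nM
compound 3, `C=CC(=O)Nc1cccc(NC(=O)CSc2nc(Nc3cccc(Cl)c3)c3ccccc3n2)c1`: 16300 nM

All three numbers sit close together. Compound 3 stands second highest of the three; its nearest neighbour is compound 2, its furthest compound 1, and both gaps are within the scatter, so no order among the three compounds can be read from these values.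

Among the compounds with values here, the one step between measured compounds that differ in one place, a 2.0-fold lower number from compound 1 to compound 2 (0.29 log units; within the scatter), concerns the amide-type nitrogen and is itself within the scatter.

Compound 4, `C=CC(=O)Nc1cccc(NC(=O)CSc2nc(Nc3ccc(C(F)(F)F)cc3)c3ccccc3n2)c1`, has not yet been measured. It differs from compound 3 at a different place: 4-(trifluoromethyl)phenyl in place of 3-chlorophenyl on a nitrogen on an aromatic ring. Within the data shown here, no measured step touches this nitrogen on the aromatic ring, so the step from compound 1 to compound 2 bears on it only as a general indication that a change of aryl group at a nitrogen has so far produced nothing beyond the scatter.

Among the measured compounds shown here, with no step at this position to go on, the expected step in this assay from compound 3 to compound 4 is none beyond the scatter, a 1.0-fold lower number from compound 3 to compound 4 (0.01 log units; within the scatter). For compound 4 the expected value is 16000 nM, with a range from 5000 nM to 50000 nM.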

Compound 4, half-maximal inhibitory concentration: 11500 nM
The estimate for compound 4 lay 1.4-fold (0.14 log units) above the measured number; the range from low to high includes it.
By their numbers in this assay, from the lowest: compounds 4, 2, 3 and 1 (each within the scatter of the next, the first and the last beyond it).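

The first step read at this position, (3-chlorophenyl)amino to (4-(trifluoromethyl)phenyl)amino, gives in this assay a 1.4-fold lower number from compound 3 to compound 4 (0.15 log units; within the scatter) and so shows no difference beyond the scatter. Within the data shown here, this extends what the earlier compounds showed at the amide-type nitrogen to the nitrogen on an aromatic ring: here a 3-chlorophenyl of 7 heavy atoms gives way to a 4-(trifluoromethyl)phenyl of 10 heavy atoms, and the read-out stays within the scatter. No measurement at hand offers an explanation for this result.

Among these compounds, the single step replaces chlorine with trifluoromethyl and alters the substitution named on the phenyl ring at the same time, so the two changes cannot be read apart, and compound 3 and compound 4 alone give no trend at this position. Going by these compounds, whether an amine or a carboxylic acid on this phenyl ring, or a saturated morpholine ring in place of it, would move the number beyond the scatter remains open.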